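A few compounds are considered here, and "the series" means these few. Any claim that something is new, unique, unknown or untested is made for them only; others in the source may bear on it.

Measured compounds:
compound 1 `Oc1ccccc1/C=N/NC(=S)N1CCOCC1` — 37300 nM
compound 2 `Oc1ccc(Cl)cc1/C=N/NC(=S)N1CCOCC1` — 35300 nM
compound 3 `Oc1c(Br)cc(Br)cc1/C=N/NC(=S)N1CCOCC1` — 32600 nM

In a functional assay on SMMC-7721 cells (Homo sapiens) for antiproliferative activity, read by MTT assay, with a stated time of 72 h (on this read-out higher numbers stand for weaker inhibition and lower numbers for stronger inhibition), compound 1 gives 37300 nM, the highest of the three numbers shown, although the other two fall within the usual scatter of it. Compound 2 gives 35300 nM and compound 3, which carries bromine substituents, gives 32600 nM.

Compound 4 `COc1ccc(/C=N/NC(=S)N2CCOCC2)c(O)c1` differs from compound 1 by methoxy in place of hydrogen on an aromatic carbon. Among the compounds with values here, only one measured step bears directly on this kind of change: a 1.1-fold lower number from compound 1 to compound 2 (0.02 log units; within the scatter), a substitution of an aromatic hydrogen that left the number where it was. Compound 3 likewise sits within the scatter of compound 1. Within the data shown here, nothing in these numbers suggests that a single substituent on this aromatic ring shifts the read-out beyond the scatter, and no measured step involves a methoxy group, so a methoxy entering cannot be weighed on its own.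

Compound 4 is therefore expected to give about 35000 nM, between 15000 nM and 80000 nM, which corresponds to an expected step of a 1.1-fold lower number from compound 1 to compound 4 (0.03 log units; within the scatter) and no change beyond the scatter.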

Compound 4, half-maximal inhibitory concentration: 38300 nM
Compound 4: the middle estimate sits 1.1-fold (0.04 log units) below what was measured; the range from low to high includes it.
By their numbers in this assay, from the lowest: compounds 3, 2, 1 and 4 (each within the scatter of the next).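

In this assay, methoxy in place of hydrogen on an aromatic carbon, meta to a hydroxy group and para to a large group, gives a 1.0-fold higher number from compound 1 to compound 4 (0.01 log units; within the scatter), so compound 1 and compound 4 cannot be told apart on this read-out. Within the data shown here, this is the first measured step with a methoxy group, and it shows that a substituent with an oxygen and a carbon at this ring carbon also stays within the scatter, as the chloro step does at its own place, a 1.1-fold lower number from compound 1 to compound 2 (0.02 log units; within the scatter). No independent data bear on the reason for this result.

From the compounds shown here alone, it remains open whether an amine or a carboxylic acid on this same carbon, or a longer chain in place of methoxy, would also stay within the scatter. The compounds shown also leave open whether any change outside the aromatic ring would move the number beyond the scatter.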